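The source may hold more compounds than are shown below. What is called first, only, known or untested is meant among the compounds shown, and "the series" means these compounds.

Three compounds were examined in a functional assay on HT-29 cells (Homo sapiens) for cytotoxicity, read by MTT assay, with a stated time of 96 h; on this read-out higher numbers stand for weaker inhibition and lower numbers for stronger inhibition. Compound 1 `COC1=C[C@]23C(=CC1=O)CCN(C(=O)C(F)(F)F)C2CCc1cc(OC)c(OC)c(OC)c13`, which carries a (trifluoromethyl)carbonyl group, has the entry "not determined" (no result reported), so it offers no number. Compound 2 `COc1cc2c(cc1O)[C@@H]1CCc3cc(OC)c(OC)c(OC)c3[C@H]2CN1S(=O)(=O)c1ccc(C)cc1` gives 10800 nM, and compound 3 `COc1cc2c(c(OC)c1OC)[C@H]1CN(S(=O)(=O)c3ccc(C)cc3)[C@@H](CC2)C2=CC(=O)C(=O)C=C21` gives 6600 nM. Within the data shown here, these two values lie within the usual scatter of each other, so compound 2 stands level with the only other number available.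

Compound 4 `COc1cc2c(cc1O)[C@@H]1CCc3cc(OC)c(OC)c(OC)c3[C@H]2CN1C(=O)C(F)(F)F` has not yet been measured. It departs from compound 2 by one change, ((trifluoromethyl)carbonyl in place of (4-methylphenyl)sulfonyl on an amine nitrogen in a ring), with (trifluoromethyl)carbonyl in place of (4-methylphenyl)sulfonyl on an amine nitrogen in a ring. Among the measured compounds shown here, no measured pair shows this exchange, and compound 1 provides no number, so the expectation rests on compound 2 at 10800 nM and remains uncertain. A moderate move toward stronger inhibition is expected in this assay, with the estimated change being a 3.6-fold lower number from compound 2 to compound 4 (0.56 log units; beyond the scatter). For compound 4 the estimated value is 3000 nM, within an expected range of 500 nM to 15000 nM.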

Compound 4, half-maximal inhibitory concentration: 27800 nM
Compound 4: the middle estimate sits 9.3-fold (0.97 log units) below what was measured; measured number above the stated range.
By their numbers in this assay, from the lowest: compounds 3 and 2 (each within the scatter of the next); then compound 4.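

Among these compounds, at the amine nitrogen in a ring, the exchange of (4-methylphenyl)sulfonyl for (trifluoromethyl)carbonyl gives the first readable step at this position in this assay (a 2.6-fold higher number from compound 2 to compound 4 (0.41 log units; beyond the scatter)). The position is therefore not indifferent to what it carries: on this core, the sulfonyl group with its aromatic ring goes with the stronger inhibition of the two, though a single pair sets no pattern. No measurement available here accounts for the step.

On these data alone, it remains open whether the aromatic ring or the sulfonyl link matters more, which a methanesulfonyl or a benzoyl group on the same nitrogen could separate. Compound 1 also carries (trifluoromethyl)carbonyl, but with no number, it cannot show whether the step holds on another core.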